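Swapping a chlorophenyl for a methylpyridyl on the thiourea arm

This account rests on a few compounds, and the source may have more. Where it says the series, first, only, none or still open, it means among the compounds named here.

Compound 1, `Nc1ccccc1NC(=O)c1ccc(NC(=S)NCc2cccc(F)c2)cc1`, in an assay on isolated protein for inhibition of Nicotinamide phosphoribosyltransferase (Homo sapiens), read by fluorescence, with stated times of 5 min and 15 min (a higher number here means a weaker inhibitor, a lower number a stronger inhibitor), gives > 2000 nM, which is a limit of the assay.
Compound 2, `Nc1ccccc1NC(=O)c1ccc(NC(=S)NCc2cccnc2)cc1`, in this assay gives 116 nM.
Compound 3, `Nc1ccccc1NC(=O)c1ccc(NC(=S)NCc2cccc(Cl)c2)cc1`, in this assay gives > 2000 nM, which is a limit of the assay.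

Compound 3 therefore sits at the limit of > 2000 nM in this assay, at which 2 of the 3 values shown sit, with no number of its own. Compound 4, `Cc1ccc(CNC(=S)Nc2ccc(C(=O)Nc3ccccc3N)cc2)cn1`, is not yet measured; it differs from compound 3 in that (6-methylpyridin-3-yl in place of 3-chlorophenyl on a saturated chain carbon bound to an amide-type nitrogen). The measured steps that bear on this are an at least 17-fold higher number from compound 2 to compound 3 (1.23 log units; beyond the scatter) and an at least 17-fold lower number from compound 1 to compound 2 (1.23 log units; beyond the scatter), both large, while a step that the two limits leave unreadable from compound 1 to compound 3 adds nothing readable. Compound 2 carries pyridin-3-yl in that same place and gives 116 nM. A step of roughly that size, in the favourable direction, is expected for compound 4, namely an at least 13-fold lower number from compound 3 to compound 4 (1.12 log units; beyond the scatter). Compound 4 is thus estimated at 150 nM, in the range 40 nM to 600 nM.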

Compound 4, half-maximal inhibitory concentration: > 2000 nM
Compound 4 was reported as a limit; the forecaster's own chance of this, stated with the estimate: 10%; middle value at least 13-fold (1.12 log units) from the limit.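

A single added methyl is enough to lose what the pyridin-3-yl group gave: methyl in place of hydrogen on an aromatic carbon produces an at least 17-fold higher number from compound 2 to compound 4 (1.23 log units; beyond the scatter). A pyridine-type ring on this arm therefore does not by itself secure the activity of compound 2. Compound 4 stops at a limit, so its steps from the other two compounds held at that limit cannot be read: the limit of > 2000 nM in this assay, at which 3 of the 4 values shown sit.

Open, going by these compounds, is how far beyond that limit compound 4 lies. Also open, on these data alone, is whether an amine or a methoxy group in place of that methyl would restore activity.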